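Replacing the selenol of compound 1 with methylsulfanyl

The source may report more compounds than this note shows. Statements on the series, on what has been measured and on what is new or still open speak of the compounds shown alone.

Measured so far:
- compound 1 `COc1ccc(CNc2nc([SeH])nc3ccccc23)cc1`: > 100000 nM
- compound 2 `[SeH]c1nc(NCc2ccccc2)c2ccccc2n1`: 63600 nM

Compound 1 has the structure `COc1ccc(CNc2nc([SeH])nc3ccccc23)cc1`. In an ADME assay on 184B5 cells (Homo sapiens) for cytotoxicity, read by MTT assay, with a stated time of 72 h (on this read-out higher numbers stand for weaker inhibition of growth and lower numbers for stronger inhibition of growth), compound 1 gives only a limit, > 100000 nM, which is not a number but the edge of what the assay reports, as shown by the limit of > 100000 nM in this assay, at which 1 of the 2 values shown sits. Compound 2 `[SeH]c1nc(NCc2ccccc2)c2ccccc2n1` differs from it by hydrogen in place of methoxy on an aromatic carbon, and in this assay compound 2 gives 63600 nM. The step of an at least 1.5-fold lower number from compound 1 to compound 2 (0.19 log units; that floor lies within the scatter) stays within the scatter.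

Compound 3 `COc1ccc(CNc2nc(SC)nc3ccccc23)cc1` is not yet measured. It differs from compound 1 by a group of 2 heavy atoms (1 carbon, 1 sulfur; no ring) in place of one selenium atom, on an aromatic carbon. No measured step touches this change; the only step shown, between compound 1 and compound 2, concerns a different place and lies within the scatter. For compound 3 the expectation is therefore no step beyond the scatter, that is a number no higher from compound 1 to compound 3 (the limit leaves the size open). Compound 3 is estimated at 100000 nM, with a range from 40000 nM to 250000 nM.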

Compound 3, concentration for total growth inhibition: > 100000 nM
Compound 3: no number, only a limit; the forecaster's own chance of this, stated with the estimate: 60%; the middle value sits exactly at the limit.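

Compound 1 and compound 3 both end at a limit of the assay rather than at a number, so no step between them can be read: the limit of > 100000 nM in this assay, at which 2 of the 3 values shown sit.

The compounds shown leave open whether methylsulfanyl in place of the selenium atom changes growth inhibition in this assay at all.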